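Adding a trifluoromethyl group to compound 2

The source may hold more compounds than are shown below. What is called first, only, known or untested is meant among the compounds shown, and "the series" means these compounds.

Compound 1 `O=C1/C(=C/c2ccncc2)CN(S(=O)(=O)c2ccc(C(F)(F)F)cc2)C/C1=C\c1ccccc1F` gives 18600 nM
Compound 2 `O=C1/C(=C/c2ccncc2)CN(S(=O)(=O)c2ccccc2)C/C1=C\c1ccccc1C(F)(F)F` gives 12300 nM

In an ADME assay on L02 cells (Homo sapiens) for cytotoxicity, read by MTT assay, with a stated time of 24 h (on this read-out higher numbers stand for weaker inhibition and lower numbers for stronger inhibition), compound 2 gives 12300 nM and so lies within the scatter of compound 1 at 18600 nM on this scale. Compound 3 `O=C1/C(=C/c2ccncc2)CN(S(=O)(=O)c2ccc(C(F)(F)F)cc2)C/C1=C\c1ccccc1C(F)(F)F` differs from compound 2 by trifluoromethyl in place of hydrogen on an aromatic carbon in one place: trifluoromethyl in place of hydrogen on an aromatic carbon. Among the compounds with values here, no measured pair shows this change alone. Compound 1 already carries a 4-(trifluoromethyl)phenyl and gives 18600 nM with it. The a 1.1-fold higher number from compound 2 to compound 3 (0.06 log units; within the scatter) in this assay is therefore expected to stay within the scatter. Compound 3 is estimated at 14000 nM with a range from 7000 nM to 28000 nM as expected.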

Compound 3, half-maximal inhibitory concentration: 13800 nM
For compound 3 the middle estimate is 1.0-fold (0.01 log units) above the measured one, and the stated range covers the measured number.
By their numbers in this assay, from the lowest: compounds 2, 3 and 1 (each within the scatter of the next).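

In this assay, the step from phenyl to 4-(trifluoromethyl)phenyl gives a 1.1-fold higher number from compound 2 to compound 3 (0.05 log units; within the scatter) and so leaves no readable difference at this position. Trifluoromethyl in place of fluoro on an aromatic carbon elsewhere in the molecule gives a 1.3-fold lower number from compound 1 to compound 3 (0.13 log units; within the scatter) and likewise stays within the scatter, so neither single change separates these compounds on this read-out. Nothing available here explains these results.

From the compounds shown here alone, whether an amine, a carboxylic acid or a longer chain at this position would give a number beyond the scatter remains open. The same question stands for a methoxy group.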